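A Phenyl Swap in a Set at the Assay Limit

A few compounds are considered here, and "the series" means these few. Any claim that something is new, unique, unknown or untested is made for them only; others in the source may bear on it.

Measured in a functional assay on HT-29 cells (Homo sapiens) for antiproliferative activity, read by CCK-8 assay, with a stated time of 24 h; a lower number here means a stronger inhibitor, a higher number a weaker inhibitor:
- Compound 1 `COC(=O)[C@]1(Cc2ccc3c(c2)CC(C(C)(C)O)O3)OC(=O)C(O)=C1c1ccccc1`: > 20000 nM (a limit)
- Compound 2 `CC(C)(O)C1Cc2cc(C[C@H]3OC(=O)C(O)=C3c3ccc(O)cc3)ccc2O1`: > 20000 nM (a limit)
- Compound 3 `COC(=O)[C@]1(Cc2ccc(O)c(CC=C(C)C)c2)OC(=O)C(O)=C1c1ccc(O)c(CC=C(C)C)c1`: > 20000 nM (a limit)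

Compound 3 stands at > 20000 nM, which is a limit of the assay and not a number. It has no measured neighbour to set it against, for the whole set shares one reading: the limit of > 20000 nM in this assay, at which 3 of the 3 values shown sit.

Compound 4 `COC(=O)[C@]1(Cc2ccc(O)c(CC=C(C)C)c2)OC(=O)C(O)=C1c1ccccc1` has phenyl in place of 4-hydroxy-3-(3-methylbut-2-en-1-yl)phenyl on a double-bonded ring carbon.

For the measured compounds named here, no measured step gives a size for this change. Compound 1 already carries phenyl on that ring carbon and reads > 20000 nM, again a limit. No change beyond the scatter is therefore expected in this assay, in either direction. The estimated step is a step that the limit leaves unreadable from compound 3 to compound 4. The assay will most likely report only a limit again. As a number, compound 4 is expected at 30000 nM, within an estimated range of 12000 nM to 60000 nM.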

Compound 4, half-maximal inhibitory concentration: > 20000 nM
Compound 4 was reported as a limit; the forecaster's own chance of this, stated with the estimate: 85%; the middle value lies beyond the limit too.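

Compound 4 gives only a limit in this assay, as compound 3 does, so no step between them can be read: the limit of > 20000 nM in this assay, at which 4 of the 4 values shown sit.

The compounds shown leave open whether phenyl or 4-hydroxy-3-(3-methylbut-2-en-1-yl)phenyl on that ring carbon makes any difference to the activity.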